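A few compounds are considered here, and "the series" means these few. Any claim that something is new, unique, unknown or untested is made for them only; others in the source may bear on it.

Measured so far in a functional assay on MCF7 cells (Homo sapiens) for cytotoxicity, read by CCK-8 assay, with a stated time of 48 h; a higher number here means a weaker inhibitor, a lower number a stronger inhibitor:
compound 1 `NS(=O)(=O)c1ccc(/N=C/c2c(Cl)c3ccccc3oc2=O)cc1` gives 120 nM;
compound 2 `O=c1oc2ccccc2c(Cl)c1/C=N/c1ccc(S(=O)(=O)Nc2nccs2)cc1` gives 160 nM;
compound 3 `Cc1ccc2oc(=O)c(/C=N/c3ccc(S(N)(=O)=O)cc3)c(Cl)c2c1` gives 270 nM.

Compound 3 sits at the upper end of these three numbers: the step of a 2.3-fold higher number from compound 1 to compound 3 (0.35 log units; beyond the scatter) is beyond the scatter, whereas the gap between compound 3 and compound 2 stays within it, so those two cannot be told apart.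

Compound 4 `Cc1ccc2oc(=O)c(/C=N/c3ccc(S(=O)(=O)Nc4nccs4)cc3)c(Cl)c2c1` is compound 3 with one change: 1,3-thiazol-2-yl in place of hydrogen on a sulfonamide nitrogen. The same change has been made once before, in the step of a 1.3-fold higher number from compound 1 to compound 2 (0.12 log units; within the scatter), which stayed within the scatter. On that one precedent the step of a 1.3-fold higher number from compound 3 to compound 4 (0.11 log units; within the scatter) is expected to be small and upward if anything, not clearly beyond the scatter. Compound 4 is therefore estimated at 350 nM, with a likely range from 180 nM to 700 nM.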

Compound 4, half-maximal inhibitory concentration: 33 nM
Estimate against measurement, compound 4: 11-fold (1.03 log units) above, and the stated range ends above it.
By their numbers in this assay, from the lowest: compound 4; then compounds 1, 2 and 3 (each within the scatter of the next, the first and the last beyond it).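

In this assay, 1,3-thiazol-2-yl in place of hydrogen on a sulfonamide nitrogen gives an 8.2-fold lower number from compound 3 to compound 4 (0.91 log units; beyond the scatter), so this change does not carry a fixed size from one core to another: the same change on two cores in this assay, a 1.3-fold higher number (0.12 log units; within the scatter) from compound 1 to compound 2 and an 8.2-fold lower number (0.91 log units; beyond the scatter) from compound 3 to compound 4, 11-fold (1.04 log units) apart, beyond the scatter of two such steps

Methyl in place of hydrogen on an aromatic carbon also turns the other way once the 1,3-thiazol-2-yl is present, giving a 4.8-fold lower number from compound 2 to compound 4 (0.69 log units; beyond the scatter): the same change on two cores in this assay, a 2.3-fold higher number (0.35 log units; beyond the scatter) from compound 1 to compound 3 and a 4.8-fold lower number (0.69 log units; beyond the scatter) from compound 2 to compound 4, 11-fold (1.04 log units) apart, beyond the scatter of two such steps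

The two changes therefore do not simply add up, as the effect of each depends on the other.

On these data alone, whether the same holds for a pyridin-2-yl or an acetyl group on the sulfonamide nitrogen, or for a methoxy group in place of the methyl, stays open. These four compounds cannot tell what lies behind this dependence.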